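The source may hold more compounds than are shown below. What is called first, only, known or untested is meant among the compounds shown, and "the series" means these compounds.

Measured compounds in the set:

compound 1: `Oc1ccc(/C=N/NC(=S)Nc2nc3ccc(Cl)cc3s2)cc1` — 100 mg/kg
compound 2: `O=C(CN(c1ccccc1)c1ccccc1)Nc1nc2ccc(Cl)cc2s1` — 300 mg/kg
compound 3: `O=[N+]([O-])c1ccc(/C=N/NC(=S)Nc2nc3ccc(Cl)cc3s2)cc1` — 100 mg/kg

All three share the same core and were tested in a functional assay on the whole organism with Mus musculus as the target, in the maximal electroshock model, with a stated time of 0.5 h; on this read-out lower numbers stand for an effect already at smaller amounts and higher numbers for an effect only at larger amounts of compound. Compound 1 gives 100 mg/kg, and compound 3 gives 100 mg/kg, so the two stand level at the digits shown and together form the lowest pair of the three numbers. Compound 2 gives 300 mg/kg, a higher number that lies beyond the scatter from compound 1.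

The unmeasured compound 4 is `S=C(N/N=C/c1ccccc1Cl)Nc1nc2ccc(Cl)cc2s1`. Relative to compound 1 it differs in one place: 2-chlorophenyl in place of 4-hydroxyphenyl on a carbon with a double bond to nitrogen. Among the measured compounds shown here, only one measured step speaks to this position: no change at the digits printed from compound 1 to compound 3 (within the scatter). That step exchanged one group on the same aromatic ring for another and left the number unchanged within the scatter. Compound 2 differs from compound 1 in more than one place, so its value gives no clean guidance here. Because no change at the digits printed from compound 1 to compound 3 (within the scatter) showed no movement when the group on that ring was exchanged, the exchange in compound 4 is expected to leave this assay about where compound 1 stands, with no step beyond the scatter in either direction. Compound 4 is therefore estimated at 100 mg/kg, within a range of 50 mg/kg to 300 mg/kg. The step this estimate implies, no change at the digits printed from compound 1 to compound 4 (within the scatter), is expected to fall inside the usual scatter.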

Compound 4, minimum effective dose: 300 mg/kg
The estimate for compound 4 lay 3.0-fold (0.48 log units) below the measured number; the measured number falls inside the stated range.
By their numbers in this assay, from the lowest: compounds 1 and 3 (each within the scatter of the next); then compounds 2 and 4 (each within the scatter of the next).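

In this assay the exchange of 4-hydroxyphenyl for 2-chlorophenyl on a carbon with a double bond to nitrogen gives a 3.0-fold higher number from compound 1 to compound 4 (0.48 log units; beyond the scatter) and so shows that this position does respond to what it carries, which could not be seen from no change at the digits printed from compound 1 to compound 3 (within the scatter) alone. The two steps together show that the outcome depends on the particular group: one exchange leaves the number in place and the other moves it beyond the scatter. The leaving group counts 1 hydrogen-bond donor and 1 hydrogen-bond acceptor while the entering group counts 0 of each, but no measurement here ties the step to that difference or to any other cause.

Among the compounds shown here, a 4-chlorophenyl group at this place would separate the effect of the chlorine from that of where it stands on the ring, a question that the single step from compound 1 to compound 4 leaves open. As far as these compounds go, how the number responds to an amine or a carboxylic acid on this ring also remains open, as does whether a group can bring it lower than the level shared by compound 1 and compound 3.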